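A Ring Opened on the Sulfonamide Side Chain

The source may hold more compounds than are shown below. What is called first, only, known or untested is meant among the compounds shown, and "the series" means these compounds.

Of the compounds shown here, two sharing one core have so far been tested in an ADME assay on microsomes from liver (Homo sapiens) for metabolic stability, read by LC-MS, using NADPH, with a stated time of 60 min, tested at 10 uM; on this read-out lower numbers stand for a less stable compound and higher numbers for a more stable compound. Compound 1 `CCc1ccc(N(CC2CC2)S(=O)(=O)c2ccc3c(c2)C(=O)CC(C2CCOCC2)O3)cc1` shows 23%, the higher of the two numbers. Compound 2 `Cc1ccc(N(C2CCC2)S(=O)(=O)c2ccc3c(c2)C(=O)CC(C2CCOCC2)O3)c(C)c1` shows 4.5%, a gap that lies beyond the usual scatter of such measurements.

Compound 3 `CCc1ccc(N(CC(C)C)S(=O)(=O)c2ccc3c(c2)C(=O)CC(C2CCOCC2)O3)cc1` has not yet been measured. It departs from compound 1 by a single change, isopropyl in place of cyclopropyl on a saturated chain carbon bound to a sulfonamide nitrogen. Cut one bond further out, the same change reads cyclopropylmethyl to isobutyl.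

Among the compounds with values here, no measured pair isolates this change, so the expectation rests on thin evidence. Within the data shown here, the starting point is compound 1 at 23%, and the only other number available is compound 2 at 4.5%, so a modest move toward the lower end seems the likeliest outcome. The expected step in this assay is a number 7 percentage points lower from compound 1 to compound 3 (within the scatter), small and pointing toward lower stability. For compound 3 the estimate is 16%, with an expected range from 5% to 32%.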

Compound 3, percent of the compound remaining: 3.2%
The estimate for compound 3 lay 12.8 percentage points above the measured number; the measured number lies below the stated range.
By their numbers in this assay, from the lowest: compounds 3 and 2 (each within the scatter of the next); then compound 1.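

In this assay, within the data shown here, the change from cyclopropylmethyl to isobutyl on the sulfonamide nitrogen gives a number 19.8 percentage points lower from compound 1 to compound 3 (beyond the scatter), and this is the first step here that isolates a single change at this position. Both the group that leaves and the group that enters count 3 heavy atoms, all carbon, and neither carries hydrogen-bond donors or acceptors, so the read-out at this position responds to a difference that leaves all of these counts unchanged, the three-membered ring being the counted feature that goes. Nothing measured on these compounds accounts for this step.

What the compounds shown leave open is whether a cyclobutylmethyl group or a straight butyl chain in the same place would stand nearer compound 1 or nearer compound 3 in this assay. Going by these compounds, compound 2 differs from compound 1 in more than one place, and whether the same step would hold with a different group on the aromatic ring carrying the ethyl group, such as a methoxy group in place of the ethyl, remains open.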